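From isopropylamino to diethylamino: an expected step

The source may hold more compounds than are shown below. What is called first, only, known or untested is meant among the compounds shown, and "the series" means these compounds.

Measured in a functional assay on A549 cells (Homo sapiens) for antiproliferative activity, read by MTT assay, with a stated time of 72 h; a higher number here means a weaker inhibitor, a lower number a stronger inhibitor:
compound 1 `CC(C)NC(=N)NC(=N)Nc1ccc(C(F)(F)F)cc1`: 3600 nM
compound 2 `CC(C)NC(=N)NC(=N)Nc1ccc(F)cc1`: 7500 nM
compound 3 `N=C(NC(=N)NC1CCCC1)Nc1ccc(F)cc1F`: 4000 nM

Compound 1 has the lowest number of the three, although its gap to compound 3 lies within the scatter. Compound 2 stands apart, with a 2.1-fold higher number from compound 1 to compound 2 (0.32 log units; beyond the scatter). Compound 4 `CCN(CC)C(=N)NC(=N)Nc1ccc(C(F)(F)F)cc1` carries diethylamino in place of isopropylamino on a carbon with a double bond to nitrogen. For the measured compounds named here, the only measured step is modest and concerns fluoro in place of trifluoromethyl on an aromatic carbon, so none of the data cover this change directly. No step beyond the scatter is therefore expected in this assay. The estimated outcome is a 1.3-fold higher number from compound 1 to compound 4 (0.10 log units; within the scatter). Compound 4 is expected at 4500 nM, with an estimated range of 1800 nM to 11000 nM.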

Compound 4, half-maximal inhibitory concentration: 3700 nM
For compound 4 the middle estimate is 1.2-fold (0.09 log units) above the measured one; the measured number falls inside the stated range.
By their numbers in this assay, from the lowest: compounds 1, 4, 3 and 2 (each within the scatter of the next, the first and the last beyond it).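

In this assay, diethylamino in place of isopropylamino on a carbon with a double bond to nitrogen gives a 1.0-fold higher number from compound 1 to compound 4 (0.01 log units; within the scatter). This is the first step shown at this position, and on the core of compound 1 the readout holds within the scatter even though the hydrogen-bond donor of isopropylamino is gone. Nothing measured here bears on this result.

As far as these compounds go, whether diethylamino gives the same result with fluoro in place of trifluoromethyl remains open. So does the outcome for dimethylamino or a longer chain such as dibutylamino at this position.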